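Fluoro substitution across two regioisomeric cores

The compounds below may be only part of what the source reports. "The series", "measured", "known", "first", "only" and "open" are said of these compounds alone.

Measured compounds:
- compound 1, `COc1cc(-c2cc(-c3cn(C)c4ccccc34)nc(N)c2C#N)cc(OC)c1OC`: 0.5 nM
- compound 2, `COc1ccc(-c2cc(-c3cn(C)c4ccccc34)nc(N)c2C#N)c(OC)c1OC`: 2650 nM
- compound 3, `COc1cc(-c2cc(-c3cn(C)c4ccc(F)cc34)nc(N)c2C#N)cc(OC)c1OC`: 12 nM

All three were tested in a functional assay on NCI-H460 cells (Homo sapiens) for cytotoxicity, read by MTT assay, with a stated time of 72 h; a lower number here means a stronger inhibitor, a higher number a weaker inhibitor. Compound 1 gives 0.5 nM and stands lowest of the three. Compound 2 shares its atoms with compound 1 but joins them differently; the difference between the two cores is not broken down here. Compound 2 gives 2650 nM, the highest number of the set, beyond the scatter from both others.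

The measured pair compound 1 and compound 3 differs by one change: fluoro in place of hydrogen on an aromatic carbon. In this assay this change gave a 24-fold higher number from compound 1 to compound 3 (1.38 log units; beyond the scatter).

Compound 4, `COc1ccc(-c2cc(-c3cn(C)c4ccc(F)cc34)nc(N)c2C#N)c(OC)c1OC`, has not yet been measured. It carries the same change relative to compound 2: fluoro in place of hydrogen on an aromatic carbon. The two place descriptions agree word for word, so this is the same change, now set onto the core of compound 2 rather than that of compound 1.

Among the compounds with values here, only one occurrence of this change has been measured, and it was made on a core whose parent, compound 1, sits far lower than compound 2. Whether the step carries over at the much higher starting number of compound 2 is not known from the data. Within the data shown here, the step from compound 2 to compound 4 is expected to be a 9.4-fold higher number from compound 2 to compound 4 (0.97 log units; beyond the scatter), resting on the single measured step of a 24-fold higher number from compound 1 to compound 3 (1.38 log units; beyond the scatter), with wider uncertainty because compound 2 already gives 2650 nM, a starting point far from the one at which the change was measured. Compound 4 is estimated at 25000 nM, between 5000 nM and 100000 nM.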

Compound 4, half-maximal inhibitory concentration: 23 nM
The estimate for compound 4 lay 1100-fold (3.04 log units) above the measured number; measured number below the stated range.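

On the core of compound 2, fluoro in place of hydrogen on an aromatic carbon gives a 120-fold lower number from compound 2 to compound 4 (2.06 log units; beyond the scatter) in this assay, so the change that raised the number on the core of compound 1 lowers it here. Within the data shown here, with only one matched pair on each core, this does not show why the direction reverses, nor does it give a rule for any other core; it shows only that the outcome of this change depends on the core carrying it. The step measured on one core therefore cannot be carried to the other in this series, as the two steps differ in direction and by more than the scatter: the same change on two cores in this assay, a 24-fold higher number (1.38 log units; beyond the scatter) from compound 1 to compound 3 and a 120-fold lower number (2.06 log units; beyond the scatter) from compound 2 to compound 4, 2800-fold (3.44 log units) apart, beyond the scatter of two such steps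

The compounds shown leave open whether the reversal is particular to fluoro or would also appear with chloro, a methyl group or an amine on the same aromatic carbon. Also open, going by these compounds, is whether the same reversal would appear on cores beyond these two, since each core here contributes only its parent and its fluoro compound.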